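A few compounds are considered here, and "the series" means these few. Any claim that something is new, unique, unknown or untested is made for them only; others in the source may bear on it.

Working notes on the series in a functional assay on HL-60 cells (Homo sapiens) for antiproliferative activity, read by XTT assay, with a stated time of 72 h; a lower number here means a stronger inhibitor, a higher number a weaker inhibitor.

Of the compounds shown here, three have been measured so far. Compound 1 `O=c1[nH]cnc2c1c(-c1ccoc1)cn2[C@@H]1O[C@H](CO)[C@@H](O)[C@H]1O` gives 6370 nM. Compound 2 `O=c1[nH]cnc2c1c(-c1ccsc1)cn2[C@@H]1O[C@H](CO)[C@@H](O)[C@H]1O` gives 12000 nM. Compound 3 `O=c1[nH]cnc2c1c(-c1ccco1)cn2[C@@H]1O[C@H](CO)[C@@H](O)[C@H]1O` gives 2200 nM, the lowest of the three numbers. The step of a 1.9-fold higher number from compound 1 to compound 2 (0.28 log units; within the scatter) stays within the scatter, so no order can be read between compound 1 and compound 2. The step of a 2.9-fold lower number from compound 1 to compound 3 (0.46 log units; beyond the scatter) and the step of a 5.5-fold lower number from compound 2 to compound 3 (0.74 log units; beyond the scatter) are both modest but beyond the scatter, which sets compound 3 apart from the other two on the numbers shown.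

The next compound, compound 4 `Nc1nc2c(c(-c3ccco3)cn2[C@@H]2O[C@H](CO)[C@@H](O)[C@H]2O)c(=O)[nH]1`, keeps the core of compound 3 and differs from it by amino in place of hydrogen on an aromatic carbon. Among the measured compounds shown here, none of the measured steps touches this position; all three concern the five-membered ring only, so there is no measured step on which to size the effect of an amino group here. For the measured compounds named here, with no bearing step, no change beyond the scatter is assumed, and the number for compound 4 is expected to sit close to that of compound 3. The expected step is no change at the digits printed from compound 3 to compound 4 (within the scatter). Compound 4 is estimated at 2200 nM, in a range from 500 nM to 9000 nM.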

Compound 4, half-maximal inhibitory concentration: > 20000 nM
Compound 4 ended at the assay's limit; the forecaster's own chance of this, stated with the estimate: 5%; middle value at least 9.0-fold (0.95 log units) from the limit.
By their numbers in this assay, from the lowest: compound 3; then compounds 1 and 2 (each within the scatter of the next). At a limit, above all of these: compound 4.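

In this assay, amino in place of hydrogen on an aromatic carbon between two ring nitrogen atoms brings an at least 9.0-fold higher number from compound 3 to compound 4 (0.95 log units; beyond the scatter), in the direction of a weaker inhibitor. Among the compounds shown here, this position is therefore not silent, whereas the earlier steps were all exchanges among furan-2-yl, furan-3-yl and thiophen-3-yl and could not speak to it. Compound 4 gives > 20000 nM, which is a limit of the assay and not a number: the limit of > 20000 nM in this assay, at which 1 of the 4 values shown sits.

The compounds shown leave open whether this shift belongs to amino in particular or would appear with any group at this carbon, a question that a methyl, a chlorine or a methoxy here would help to settle, and how far the number for compound 4 actually lies from that of compound 3. As far as these compounds go, it also remains open whether amino at this carbon would act in the same way with furan-3-yl or thiophen-3-yl in place of furan-2-yl, since only the furan-2-yl pair is available for this change.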